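This account rests on a few compounds, and the source may have more. Where it says the series, first, only, none or still open, it means among the compounds named here.

Among the compounds with values here, in an assay for inhibition of serine/threonine-protein kinase Sgk1 (Homo sapiens), with stated times of 30 min and 60 min, in the presence of a further agent that is not named here (a lower number here means a stronger inhibitor, a higher number a weaker inhibitor), three compounds have numbers so far. Within the data shown here, compound 1 `NC(=O)c1cc(-c2ccc(NS(=O)(=O)c3cccc(Cl)c3Cl)cc2)nc2[nH]ncc12` gives 236 nM, and compound 2 `CN(C)CCCNC(=O)c1cc(-c2ccc(NS(=O)(=O)c3cccc(Cl)c3Cl)cc2)nc2[nH]ncc12` gives 633 nM, the single measured step being a 2.7-fold higher number from compound 1 to compound 2 (0.43 log units; beyond the scatter). Compound 3 `Cc1n[nH]c2nc(-c3ccc(NS(=O)(=O)c4cc(Cl)ccc4F)cc3)nc(OCC(CO)CO)c12` gives 2 nM, the lowest number of the three, beyond the scatter from both compound 1 and compound 2. Compound 4 `Cc1n[nH]c2nc(-c3ccc(NS(=O)(=O)c4cc(Cl)ccc4F)cc3)nc(OC3CC(C)(C)N(C)C(C)(C)C3)c12` differs from compound 3 by 1,2,2,6,6-pentamethylpiperidin-4-yl in place of 3-hydroxy-2-(hydroxymethyl)propyl on an oxygen on an aromatic ring. Among the measured compounds shown here, the one measured step, from compound 1 to compound 2, sits on another core and on an amide nitrogen rather than an aryl oxygen, so it bears only loosely here, and it was modest in size. On that thin basis the expected step is a 2.5-fold higher number from compound 3 to compound 4 (0.40 log units; beyond the scatter), a small rise in the number. For compound 4 the estimate is 5 nM, with a range from 1 nM to 25 nM.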

Compound 4, half-maximal inhibitory concentration: 3 nM
For compound 4 the middle estimate is 1.7-fold (0.22 log units) above the measured one, and the stated range covers the measured number.
By their numbers in this assay, from the lowest: compounds 3 and 4 (each within the scatter of the next); then compound 1; then compound 2.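

In this assay, putting 1,2,2,6,6-pentamethylpiperidin-4-yl in place of 3-hydroxy-2-(hydroxymethyl)propyl gives a 1.5-fold higher number from compound 3 to compound 4 (0.18 log units; within the scatter), a step within the scatter. This oxygen on the shared core can therefore carry either a ringless chain with 2 hydrogen-bond donors or a larger six-membered ring with 0 donors, with no difference beyond the scatter. The information available gives no reason for this result. Still open, on these data alone, is whether a group as small as methyl, or a longer chain ending in a carboxylic acid, would give a number in the same range.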